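Sulfonyl aryl swap on the acylsulfonylurea series

This account rests on a few compounds, and the source may have more. Where it says the series, first, only, none or still open, it means among the compounds named here.

Compound 1, `O=C(NC/C=C1\CCCc2cnn(Cc3ccc(Cl)cc3Cl)c21)NS(=O)(=O)c1ccc(Cl)cc1`, gives 12 nM in a functional assay on CHO-K1 cells for antagonist activity at prostaglandin E2 receptor EP3 subtype (Homo sapiens), read by TR-FRET and cAMP accumulation, with a stated time of 30 min; a lower number here means a stronger inhibitor, a higher number a weaker inhibitor.
Compound 2, `Cc1ncc(S(=O)(=O)NC(=O)NC/C=C2\CCCc3cnn(Cc4ccc(Cl)cc4Cl)c32)s1`, gives 9 nM in this assay.

Within the data shown here, compound 2 and compound 1 sit within the scatter of each other in this assay; the one measured step, a 1.3-fold lower number from compound 1 to compound 2 (0.12 log units; within the scatter), exchanges the aryl group on the sulfonyl sulfur without a change beyond the scatter. Compound 3, `O=C(NC/C=C1\CCCc2cnn(Cc3ccc(Cl)cc3Cl)c21)NS(=O)(=O)c1cccs1`, carries thiophen-2-yl in place of 2-methyl-1,3-thiazol-5-yl on a sulfonyl sulfur, again a change at that sulfonyl sulfur. Among the measured compounds shown here, the single relevant step being within the scatter, a step of no more than the scatter is expected here too: a 1.1-fold higher number from compound 2 to compound 3 (0.05 log units; within the scatter). Compound 3 is estimated at 10 nM, with a range of 4 nM to 25 nM.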

Compound 3, half-maximal inhibitory concentration: 28 nM
For compound 3 the middle estimate is 2.8-fold (0.45 log units) below the measured one; the measured number lies above the stated range.
By their numbers in this assay, from the lowest: compounds 2 and 1 (each within the scatter of the next); then compound 3.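

The position on the sulfonyl sulfur does respond to the aryl group in this assay: thiophen-2-yl gives a 3.1-fold higher number from compound 2 to compound 3 (0.49 log units; beyond the scatter) and also a 2.3-fold higher number from compound 1 to compound 3 (0.37 log units; beyond the scatter) and so stands apart from both earlier groups, though both steps are modest. The earlier pair, 4-chlorophenyl and 2-methyl-1,3-thiazol-5-yl, had shown no change beyond the scatter. No measurement shown accounts for this difference. Still open, on these data alone, is whether the methyl group or the ring nitrogen of 2-methyl-1,3-thiazol-5-yl matters here, which unsubstituted 1,3-thiazol-5-yl and 5-methylthiophen-2-yl would separate.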